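Cyclopentyl for indanyl on the shared core

A few compounds are considered here, and "the series" means these few. Any claim that something is new, unique, unknown or untested is made for them only; others in the source may bear on it.

Compound 1 `NS(=O)(=O)OC[C@@H]1C[C@@H](n2nnc3c(N[C@H]4CCc5ccccc54)ncnc32)C[C@@H]1O` gives 0.21 nM in an assay on a protein complex for inhibition of NEDD8 activating enzyme (Homo sapiens), read by HTRF, with a stated time of 2 h, in the presence of a further agent that is not named here (a lower number here means a stronger inhibitor, a higher number a weaker inhibitor), the lowest number of the two measured. Compound 2 `NS(=O)(=O)OC[C@@H]1C[C@@H](n2nnc3c(NCCCc4ccccc4)ncnc32)C[C@@H]1O` gives 149 nM; the step of a 710-fold higher number from compound 1 to compound 2 (2.85 log units; beyond the scatter) is large. Compound 3 `NS(=O)(=O)OC[C@@H]1C[C@@H](n2nnc3c(NC4CCCC4)ncnc32)C[C@@H]1O` differs from compound 1 by cyclopentyl in place of 2,3-dihydro-1H-inden-1-yl on a nitrogen on an aromatic ring. Among the compounds with values here, only the step from compound 1 to compound 2 bears on this, and it replaced the same group with an open chain, so a weaker hit is expected here, still well beyond the scatter. The estimate for compound 3 is 5 nM, range 0.8 nM to 40 nM, a step of a 24-fold higher number from compound 1 to compound 3 (1.38 log units; beyond the scatter).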

Compound 3, half-maximal inhibitory concentration: > 10000 nM
Compound 3: a limit, no number (the forecaster's own chance of this, stated with the estimate: 2%); middle value at least 2000-fold (3.30 log units) away from the limit.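

Compound 3 stands at a limit of the assay, not at a number: the limit of > 10000 nM in this assay, at which 1 of the 3 values shown sits. On the nitrogen on an aromatic ring, cyclopentyl gives an at least 47000-fold higher number from compound 1 to compound 3 (4.67 log units; beyond the scatter), and replacing 3-phenylpropyl with it gives an at least 67-fold higher number from compound 2 to compound 3 (1.82 log units; beyond the scatter), so the open chain of compound 2 still outranks this smaller ring. Among these three compounds, the two whose groups carry a six-membered aromatic ring give measured numbers, and none goes against this.

Still open, as far as these compounds go, is whether the aromatic ring or the heavy-atom count tracks with the drop. A cyclohexyl or benzyl group at this place would help separate the two.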